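Methoxy to methylsulfanyl on the aryl of compound 2

This account rests on a few compounds, and the source may have more. Where it says the series, first, only, none or still open, it means among the compounds named here.

Measured so far:
compound 1 `COc1cc(-c2ncnn2-c2ccc(Cl)c(Cl)c2)cc(OC)c1OC` — > 10000 nM
compound 2 `COc1ccc(-c2ncnn2-c2cc(OC)c(OC)c(OC)c2)cc1` — 360 nM
compound 3 `CCOc1ccccc1-c1ncnn1-c1cc(OC)c(OC)c(OC)c1` — > 10000 nM

Going by the values given here, in a functional assay on MCF7 cells (Homo sapiens) for antiproliferative activity, read by MTT assay, with a stated time of 72 h (a higher number here means a weaker inhibitor, a lower number a stronger inhibitor), compound 2 is the only member of the series with a measured number. Compound 1 gives only a limit, > 10000 nM. Compound 3 likewise gives only a limit, > 10000 nM. Among the compounds with values here, two of the three values thus sit at the limit of > 10000 nM in this assay, at which 2 of the 3 values shown sit, so compound 2 is the sole anchor for any comparison.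

Compound 4 `COc1cc(-n2ncnc2-c2ccc(SC)cc2)cc(OC)c1OC` differs from compound 2 in one place: methylsulfanyl in place of methoxy on an aromatic carbon. Within the data shown here, no measured step of this kind exists. The change is expected to move potency little, within the scatter or at most slightly either way. Compound 4 is therefore estimated at 300 nM (range 80 nM to 1500 nM), a step of a 1.2-fold lower number from compound 2 to compound 4 (0.08 log units; within the scatter) in this assay.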

Compound 4, half-maximal inhibitory concentration: 390 nM
Compound 4: middle estimate off by 1.3-fold (0.11 log units), on the low side; measured number inside the range.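

In this assay, the exchange of 4-methoxyphenyl for 4-(methylsulfanyl)phenyl gives a 1.1-fold higher number from compound 2 to compound 4 (0.03 log units; within the scatter). Going by these compounds alone, this is the first measured single change, and it shows that methylsulfanyl can stand in place of methoxy here with no step beyond the scatter. Nothing at hand bears on why the two groups read alike.

Open, as far as these compounds go, is whether this tolerance reaches beyond these two groups, for example to ethylsulfanyl, a dimethylamine or a carboxylic acid at the same position. A single exchange also cannot show how far other changes on this ring would be tolerated.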